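The compounds below may be only part of what the source reports. "The series", "measured", "known", "first", "only" and "open" are said of these compounds alone.

In a functional assay on HL-60 cells (Homo sapiens) for cytotoxicity, read by MTT assay, with a stated time of 24 h (a lower number here means a stronger inhibitor, a higher number a weaker inhibitor), the measured compounds give:
compound 1 `BrCCCOc1c(Br)cc(Br)cc1Oc1ccc(Br)cc1Br` gives 29.9 ug/mL
compound 2 `OCCCOc1c(Br)cc(Br)cc1Oc1ccc(Br)cc1Br` gives 29.9 ug/mL
compound 3 `CC(C)(C)C(=O)C(C#N)Oc1c(Br)cc(Br)cc1Oc1ccc(Br)cc1Br` gives 29.2 ug/mL

Compound 3 cannot be told apart from the other two (a 1.0-fold lower number from compound 1 to compound 3 (0.01 log units; within the scatter) and a 1.0-fold lower number from compound 2 to compound 3 (0.01 log units; within the scatter)). Compound 4 `C=CCOc1c(Br)cc(Br)cc1Oc1ccc(Br)cc1Br` carries allyl in place of cyano((tert-butyl)carbonyl)methyl on an oxygen on an aromatic ring. Among the measured compounds shown here, all the measured steps changed the group on that oxygen, including the one with no change at the digits printed from compound 1 to compound 2 (within the scatter) as its result, and none left the scatter. On this evidence, no step beyond the scatter is expected in this assay, in either direction. An estimated 1.0-fold lower number from compound 3 to compound 4 (0.00 log units; within the scatter) is what follows. For compound 4 the expected value is 29 ug/mL (estimated range 16 ug/mL to 50 ug/mL).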

Compound 4, half-maximal inhibitory concentration: 27.9 ug/mL
Estimate against measurement, compound 4: 1.0-fold (0.02 log units) above, within the range that was stated.
By their numbers in this assay, from the lowest: compounds 4, 3, 1 and 2 (each within the scatter of the next).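

In this assay, the step of a 1.0-fold lower number from compound 3 to compound 4 (0.02 log units; within the scatter) shows that on this oxygen on an aromatic ring, cyano((tert-butyl)carbonyl)methyl, with 9 heavy atoms and 2 hydrogen-bond acceptors, gives way to allyl, with 3 heavy atoms and 0 hydrogen-bond acceptors, without leaving the scatter. Vinyl in place of 2-hydroxyethyl, a 1.1-fold lower number from compound 2 to compound 4 (0.03 log units; within the scatter), and vinyl in place of 2-bromoethyl, a 1.1-fold lower number from compound 1 to compound 4 (0.03 log units; within the scatter), stay within it too. Nothing available accounts for this lack of movement.

The compounds shown leave open whether an amine, a carboxylic acid or a longer chain on this oxygen would move the number beyond the scatter. From the compounds shown here alone, whether a change on the shared core would do so also stays open.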